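Amine chain lengthening on the compound 2 scaffold

A few compounds are considered here, and "the series" means these few. Any claim that something is new, unique, unknown or untested is made for them only; others in the source may bear on it.

In a toxicity assay on CHO cells (Cricetulus griseus) for cytotoxicity, read by WST assay, with a stated time of 24 h (on this read-out higher numbers stand for weaker inhibition and lower numbers for stronger inhibition), compound 1 `CC(C)=CCCC(C)=CCNCCN` gives 36200 nM and compound 2 `CC(C)=CCC/C(C)=C\CCC(C)=CCNCCN` gives 32300 nM. Compound 2 therefore stands within the scatter of compound 1, and the two numbers cannot be told apart.

Compound 3 `CC(C)=CCC/C(C)=C\CCC(C)=CCNCCCCN` keeps the unsaturated chain of compound 2 and changes the other part of the molecule: 2-aminoethyl in place of amino on a saturated chain carbon, two bonds along the chain from an amine nitrogen. In words, this is 2-aminoethyl in place of amino on a saturated chain carbon, two bonds along the chain from an amine nitrogen.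

Among the measured compounds shown here, only one measured step is available, a 1.1-fold lower number from compound 1 to compound 2 (0.05 log units; within the scatter), and it lies within the scatter. For the measured compounds named here, it concerns a different place in the molecule, so it bears on the new change only indirectly, and no measured step tests this change directly. Going by the values given here, with that one step as the only guide, no shift beyond the scatter is expected, and the direction remains open. The estimated step is a 1.2-fold lower number from compound 2 to compound 3 (0.06 log units; within the scatter). The expected value for compound 3 is 28000 nM, with an estimated range of 12000 nM to 60000 nM.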

Compound 3, half-maximal inhibitory concentration: 18100 nM
For compound 3 the middle estimate is 1.5-fold (0.19 log units) above the measured one, within the range that was stated.
By their numbers in this assay, from the lowest: compounds 3, 2 and 1 (each within the scatter of the next).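

In this assay, among the compounds shown here, the exchange of amino for 2-aminoethyl gives a 1.8-fold lower number from compound 2 to compound 3 (0.25 log units; within the scatter) and is the first measured step at this place, on a saturated chain carbon, two bonds along the chain from an amine nitrogen. The entering group has 3 heavy atoms where the leaving group has 1 heavy atom, with the same hydrogen-bond donor and acceptor counts and no net charge, and this enlargement gives no number that can be told apart from that of compound 2. With a 1.1-fold lower number from compound 1 to compound 2 (0.05 log units; within the scatter) at the other place, both single changes in this short series now lie within the scatter, and no data shown here give a reason for this insensitivity.

Still open, from the compounds shown here alone, is whether a longer chain at this place, such as 6-aminohexyl, or a carboxylic acid in place of the amine, would move the number beyond the scatter. Also open, going by these compounds, is whether 2-aminoethyl in place of amino gives a comparable step on the shorter unsaturated chain of compound 1.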